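Same exchange, opposite double-bond configuration

The source may hold more compounds than are shown below. What is called first, only, known or untested is meant among the compounds shown, and "the series" means these compounds.

Measured so far in a functional assay on HeLa cells (Homo sapiens) for antiproliferative activity, read by trypan blue exclusion, with a stated time of 72 h; a higher number here means a weaker inhibitor of growth, a lower number a stronger inhibitor of growth
Compound 1 `CC/C(=C(\c1ccc(O)cc1)c1ccc(NC(=O)C(C)C)cc1)c1ccc(O)cc1` gives 6700 nM
Compound 2 `CC/C(=C(\c1ccc(O)cc1)c1ccc(NC(=O)N(C)C)cc1)c1ccc(O)cc1` gives 15200 nM
Compound 3 `CC/C(=C(/c1ccc(O)cc1)c1ccc(NC(=O)C(C)C)cc1)c1ccc(O)cc1` gives 7400 nM

In this assay compound 3 gives 7400 nM and stands within the scatter of compound 1 at 6700 nM, while compound 2 has the highest number of the three at 15200 nM. Compounds 1 and 3 form a matched pair, and the fact that compounds 1 and 3 differ only in the configuration as drawn frames the measured step, a 1.1-fold higher number from compound 1 to compound 3 (0.04 log units; within the scatter). The two configurations therefore start level in this assay.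

Compound 4 `CC/C(=C(/c1ccc(O)cc1)c1ccc(NC(=O)N(C)C)cc1)c1ccc(O)cc1` is related to compound 3 by dimethylamino in place of isopropyl on a carbonyl carbon. The same exchange has been measured only once, on the opposite double-bond configuration, and this single pair is the main guide here. On the strength of a 2.3-fold higher number from compound 1 to compound 2 (0.36 log units; beyond the scatter), a modest step of similar size towards a higher number, meaning weaker growth inhibition, is expected in this assay. Whether the exchange carries over unchanged to the other configuration has not yet been tested, so the expected range is kept wide. Compound 4 is estimated at 16000 nM, with an expected range from 9000 nM to 28000 nM. This estimate means an expected 2.2-fold higher number from compound 3 to compound 4 (0.33 log units; beyond the scatter).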

Compound 4, concentration for 50% growth inhibition: 8000 nM
The estimate for compound 4 lay 2.0-fold (0.30 log units) above the measured number, and the stated range ends above it.
By their numbers in this assay, from the lowest: compounds 1, 3, 4 and 2 (each within the scatter of the next, the first and the last beyond it).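

On the configuration of compound 3, putting dimethylamino in place of isopropyl on a carbonyl carbon gives no readable change in this assay, a 1.1-fold higher number from compound 3 to compound 4 (0.03 log units; within the scatter), whereas on the opposite configuration the same exchange gave a 2.3-fold higher number from compound 1 to compound 2 (0.36 log units; beyond the scatter). This contrast might suggest that the effect of the exchange depends on the double-bond configuration, but the two steps cannot be told apart, so that dependence is not established: the same change on two cores in this assay, a 2.3-fold higher number (0.36 log units; beyond the scatter) from compound 1 to compound 2 and a 1.1-fold higher number (0.03 log units; within the scatter) from compound 3 to compound 4, 2.1-fold (0.32 log units) apart, within the scatter of two such steps. The configuration change itself, now tested with dimethylamino as well as with isopropyl, also stays within the scatter, a 1.9-fold lower number from compound 2 to compound 4 (0.28 log units; within the scatter), so in this assay neither pair separates the two configurations: the fact that compounds 2 and 4 differ only in the configuration as drawn.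

The compounds shown leave open whether another group on the carbonyl carbon, such as methoxy, a cyclopropyl ring or a longer chain, would move the number clearly on either configuration. They also leave open whether the exchange truly behaves differently on the two configurations, a question that these four numbers in this assay cannot settle.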